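Series notes: aryl carbonyl swap from compound 1 to compound 4

The compounds below may be only part of what the source reports. "The series", "measured", "known", "first", "only" and "open" are said of these compounds alone.

Measured compounds:
compound 1 `CN(C(=O)NC(=O)c1cccc([N+](=O)[O-])c1)c1nc(C(F)(F)F)c(C(=O)N/N=C/c2ccccc2C(F)(F)F)s1` gives 4.73 ug/mL
compound 2 `Cc1nc(N(C)C(=O)NC(=O)c2ccc(Cl)cc2Cl)sc1C(=O)N/N=C/c1ccc(C(F)(F)F)cc1` gives 24.5 ug/mL
compound 3 `CNc1nc(C(F)(F)F)c(C(=O)N/N=C/c2cc(C(F)(F)F)cc(C(F)(F)F)c2)s1` reaches only a limit, > 100 ug/mL

Potency was read in a functional assay on MCF7 cells (Homo sapiens) for inhibition, read by MTT assay, with a stated time of 72 h; a lower number here means a stronger inhibitor, a higher number a weaker inhibitor. Compound 1 holds the lowest of the two numbers recorded; compound 2 sits at a higher value, and that gap lies beyond the usual scatter. Compound 3 stops at the limit of the assay the limit of > 100 ug/mL in this assay, at which 1 of the 3 values shown sits, and returns no number. Compound 2 carries a 2,4-dichlorophenyl on its carbonyl, yet it differs from compound 1 in other places as well, so its value cannot be read as a step for any single change.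

The unmeasured compound 4 `CN(C(=O)NC(=O)c1ccc(Cl)cc1Cl)c1nc(C(F)(F)F)c(C(=O)N/N=C/c2ccccc2C(F)(F)F)s1` departs from compound 1 in one place: 2,4-dichlorophenyl in place of 3-nitrophenyl on a carbonyl carbon. Among the measured compounds shown here, no pair of measured compounds isolates this change. The expected step of a 1.9-fold higher number from compound 1 to compound 4 (0.28 log units; within the scatter) is a modest loss, somewhat beyond the scatter but short of the gap between compound 1 and compound 2. For the measured compounds named here, this expectation is guided by compound 2, the only measured compound with a 2,4-dichlorophenyl carbonyl, which gives 24.5 ug/mL while differing elsewhere. Compound 4 is expected at 9 ug/mL, with a range of 3 ug/mL to 28 ug/mL.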

Compound 4, half-maximal inhibitory concentration: 9.12 ug/mL
Beside the measured number, compound 4's estimate is 1.0-fold (0.01 log units) below it; the range from low to high includes it.
By their numbers in this assay, from the lowest: compounds 1 and 4 (each within the scatter of the next); then compound 2. At a limit, above all of these: compound 3.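

Among the compounds shown here, on a carbonyl carbon whose other neighbours are an amide-type nitrogen, this assay now gives the one single-place step: a 1.9-fold higher number from compound 1 to compound 4 (0.29 log units; within the scatter), with 2,4-dichlorophenyl in place of 3-nitrophenyl. The two groups are therefore not told apart in this read-out, and the nitro group is not needed to keep the value of compound 1 within the scatter, since an aromatic ring carrying two chlorines serves equally well at this place. Nothing recorded for these compounds bears on what lies behind this step.

For the compounds shown here, compound 2 and compound 3 differ from the others in more than one place, so no step to either can be read, and the series still offers only this one pair for judging the carbonyl substituent. Open questions are what an unsubstituted phenyl, a pyridine, or a phenyl bearing an amine or a carboxylic acid would give at this carbonyl, and whether the swap behaves alike when the rest of the shared core is changed.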